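Chain Length and Amidine Ring Closure in a Cytotoxicity Series

The compounds below may be only part of what the source reports. "The series", "measured", "known", "first", "only" and "open" are said of these compounds alone.

Three compounds share a benzofuran-type core carrying an aryl ether chain and an amidine-type group. In an ADME assay on L6 cells (Rattus norvegicus) for cytotoxicity, read by resazurin assay, with a stated time of 70 h (on this read-out higher numbers stand for weaker inhibition and lower numbers for stronger inhibition), compound 1 `CC(C)NC(=N)c1ccc2oc(-c3ccc(OCCCOc4ccccc4)cc3)cc2c1` gives 45600 nM. Compound 2 `c1ccc(OCCCOc2ccc(-c3cc4cc(C5=NCCN5)ccc4o3)cc2)cc1` differs by a group of 5 heavy atoms (3 carbon, 2 nitrogen; one five-membered non-aromatic ring with 2 hetero atoms) in place of a group of 6 heavy atoms (4 carbon, 2 nitrogen; no ring), on an aromatic carbon and gives 10300 nM, a change of a 4.4-fold lower number from compound 1 to compound 2 (0.65 log units; beyond the scatter). Compound 3 `CC(C)NC(=N)c1ccc2oc(-c3ccc(OCCCCCCOc4ccccc4)cc3)cc2c1` differs from compound 1 by 3-phenoxypropyl in place of phenoxy on a saturated chain carbon, three bonds along the chain from an oxygen on an aromatic ring. Compound 3 gives 800 nM, a change of a 57-fold lower number from compound 1 to compound 3 (1.76 log units; beyond the scatter), which leaves compound 3 with the lowest number of the three.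

Compound 4 `c1ccc(OCCCCCCOc2ccc(-c3cc4cc(C5=NCCN5)ccc4o3)cc2)cc1` has not yet been measured. It stands to compound 3 as compound 2 stands to compound 1: the change is a group of 5 heavy atoms (3 carbon, 2 nitrogen; one five-membered non-aromatic ring with 2 hetero atoms) in place of a group of 6 heavy atoms (4 carbon, 2 nitrogen; no ring), on an aromatic carbon, and the place where it occurs is described in the same words for both pairs, so it is the same change on the two cores, which differ as given by 3-phenoxypropyl in place of phenoxy on a saturated chain carbon, three bonds along the chain from an oxygen on an aromatic ring. Because the earlier instance gave a 4.4-fold lower number from compound 1 to compound 2 (0.65 log units; beyond the scatter), the step from compound 3 to compound 4 is expected to be about a 4.0-fold lower number from compound 3 to compound 4 (0.60 log units; beyond the scatter). Compound 4 is therefore estimated at 200 nM, with a plausible range from 60 nM to 700 nM.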

Compound 4, half-maximal inhibitory concentration: 1500 nM
Compound 4: the middle estimate sits 7.5-fold (0.88 log units) below what was measured, and the stated range ends below it.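

On the core of compound 3, the swap to the five-membered ring gives a 1.9-fold higher number from compound 3 to compound 4 (0.27 log units; within the scatter) in this assay, so the clear drop seen on the core of compound 1 does not carry over to this core: the same change on two cores in this assay, a 4.4-fold lower number (0.65 log units; beyond the scatter) from compound 1 to compound 2 and a 1.9-fold higher number (0.27 log units; within the scatter) from compound 3 to compound 4, 8.3-fold (0.92 log units) apart, beyond the scatter of two such steps

The chain change, 3-phenoxypropyl in place of phenoxy, keeps its direction on the ring-bearing core, with a 6.9-fold lower number from compound 2 to compound 4 (0.84 log units; beyond the scatter), but its size does not transfer: the same change on two cores in this assay, a 57-fold lower number (1.76 log units; beyond the scatter) from compound 1 to compound 3 and a 6.9-fold lower number (0.84 log units; beyond the scatter) from compound 2 to compound 4, 8.3-fold (0.92 log units) apart, beyond the scatter of two such steps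

These two gaps come from the same four compounds and show that, in this series, the two changes do not act independently on the read-out, but they do not show why, nor whether this would hold beyond these compounds.

As far as these compounds go, it remains open whether an unsubstituted amidine or a six-membered cyclic amidine would follow the pattern of compound 2 or that of compound 4. From the compounds shown here alone, how a chain of intermediate length or a longer chain would affect the size of the ring swap also remains open.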